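The source may report more compounds than this note shows. Statements on the series, on what has been measured and on what is new or still open speak of the compounds shown alone.

Compound 1 `CC1=CC[C@@H]([C@@](C)(O)CCCC(C)(C)NC(=S)N/N=C\c2ccccc2)CC1`: 9960 nM
Compound 2 `CC1=CC[C@@H]([C@@](C)(O)CCCC(C)(C)NC(=S)N/N=C\c2ccccc2[N+](=O)[O-])CC1`: 6940 nM

In a functional assay on HT-29 cells (Homo sapiens) for cytotoxicity, read by sulforhodamine B assay (on this read-out higher numbers stand for weaker inhibition of growth and lower numbers for stronger inhibition of growth), compound 2 gives 6940 nM, within the scatter of compound 1 at 9960 nM. Compound 3 `CC1=CC[C@@H]([C@@](C)(O)CCCC(C)(C)NC(=S)N/N=C\c2ccc([N+](=O)[O-])cc2)CC1` has not yet been measured. It has the same atoms as compound 2, joined differently: 4-nitrophenyl in place of 2-nitrophenyl on a carbon with a double bond to nitrogen. Among the measured compounds shown here, only one measured step bears on this change, and only indirectly: a 1.4-fold lower number from compound 1 to compound 2 (0.16 log units; within the scatter), with nitro in place of hydrogen on an aromatic carbon. For the measured compounds named here, no measured step compares the two nitrophenyl groups directly, so the data offer no ground for expecting a shift beyond the scatter in this assay. The expected change is a 1.1-fold lower number from compound 2 to compound 3 (0.03 log units; within the scatter). For compound 3 the estimated value is 6500 nM, with an expected range from 2800 nM to 14000 nM.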

Compound 3, concentration for 50% growth inhibition: 12300 nM
Estimate against measurement, compound 3: 1.9-fold (0.28 log units) below; measured number inside the range.
By their numbers in this assay, from the lowest: compounds 2, 1 and 3 (each within the scatter of the next).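

In this assay the two nitrophenyl groups, on a carbon with a double bond to nitrogen, can now be compared directly: the exchange of 2-nitrophenyl for 4-nitrophenyl gives a 1.8-fold higher number from compound 2 to compound 3 (0.25 log units; within the scatter) and so does not carry the result beyond the scatter. Against compound 1, which has no nitro group, the 4-nitrophenyl group gives a 1.2-fold higher number from compound 1 to compound 3 (0.09 log units; within the scatter) and so also stays within the scatter, as the 2-nitrophenyl group did. No measurement at hand offers an explanation for how closely these numbers agree.

The compounds shown leave open whether an amine or a carboxylic acid in place of the nitro group would give a number beyond the scatter of these three. They also leave open whether a change elsewhere in the shared core, such as a longer chain, would do so.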